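The source may hold more compounds than are shown below. What is called first, only, known or untested is meant among the compounds shown, and "the series" means these compounds.

Compound 2 `CCCCc1cccc(=O)n1Cc1ccc(-c2ccccc2-c2nn[nH]n2)cc1` gives 4 nM in a functional assay (aorta) for antagonist activity, with Oryctolagus cuniculus as the target (on this read-out higher numbers stand for weaker inhibition and lower numbers for stronger inhibition), the second highest of the three numbers measured. Compound 1 `CCCCc1ccc(CN(Cc2ccccc2)C(C)=O)c(=O)n1Cc1ccc(-c2ccccc2-c2nn[nH]n2)cc1` gives 1 nM, and compound 3 `CCCCc1ccc(CNC(=O)OC(C)(C)C)c(=O)n1Cc1ccc(-c2ccccc2-c2nn[nH]n2)cc1` gives 10 nM. The measured steps are a 4.0-fold higher number from compound 1 to compound 2 (0.60 log units; beyond the scatter), a 2.5-fold higher number from compound 2 to compound 3 (0.40 log units; beyond the scatter) and a 10-fold higher number from compound 1 to compound 3 (1.00 log units; beyond the scatter). Compound 4 `CCCCc1ccc(CNS(C)(=O)=O)c(=O)n1Cc1ccc(-c2ccccc2-c2nn[nH]n2)cc1` differs from compound 2 by (methanesulfonamido)methyl in place of hydrogen on an aromatic carbon. The step from compound 2 to compound 3, where ((tert-butoxycarbonyl)amino)methyl replaced hydrogen on an aromatic carbon, bears most directly on this change, while the step from compound 1 to compound 2 shows that (acetyl(benzyl)amino)methyl on an aromatic carbon went with a lower number. A modest step in either direction therefore seems possible, and a slightly higher number is expected, a 1.5-fold higher number from compound 2 to compound 4 (0.18 log units; within the scatter). Compound 4 is estimated at 6 nM, within the range 2 nM to 20 nM.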

Compound 4, half-maximal inhibitory concentration: 2 nM
Beside the measured number, compound 4's estimate is 3.0-fold (0.48 log units) above it; the measured number falls inside the stated range.
By their numbers in this assay, from the lowest: compounds 1, 4 and 2 (each within the scatter of the next, the first and the last beyond it); then compound 3.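

In this assay, placing (methanesulfonamido)methyl para to the butyl group gives a 2.0-fold lower number from compound 2 to compound 4 (0.30 log units; within the scatter), so this polar-looking addition is best described simply as one that leaves the number inside the usual scatter. On the amine nitrogen, methylsulfonyl in place of tert-butoxycarbonyl gives a 5.0-fold lower number from compound 3 to compound 4 (0.70 log units; beyond the scatter), showing that what sits on that nitrogen can shift the number, whereas methanesulfonamido in place of acetyl(benzyl)amino gives a 2.0-fold higher number from compound 1 to compound 4 (0.30 log units; within the scatter). No measurement here explains these results. Going by these compounds, whether a free amine or a carboxylic acid on this methyl group would give a similar number remains open, as does the effect of a longer chain on the sulfonyl group.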